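The source may hold more compounds than are shown below. What is called first, only, known or untested is meant among the compounds shown, and "the series" means these compounds.

Values in a toxicity assay on the whole organism (J774 cells) for cytotoxicity, with Mus musculus as the target, read by MTT assay, with a stated time of 24 h, tested at 10 uM; on this read-out higher numbers stand for a weaker effect at the one concentration tested and lower numbers for a stronger effect:

compound 1, `CCCCCCCCCO[C@@H]1[C@@H](N)[C@@H](O[C@H]2[C@H](O)[C@@H](O)[C@H](N)C[C@@H]2N)O[C@H](CN)[C@H]1OCCCCCCCCC`: 82.7%
compound 2, `C=CCO[C@H]1O[C@H](CN)[C@@H](OCc2ccc3ccccc3c2)[C@H](OCc2ccc3ccccc3c2)[C@H]1N`: 86.9%

Compound 1 gives the lower of the two numbers in this assay, but the gap to compound 2 lies within the usual scatter, so the two stand together at a weak effect at the one concentration tested.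

Compound 3, `CCCCCCCCCO[C@@H]1[C@@H](N)[C@@H](OCC(O)CNCCO)O[C@H](CN)[C@H]1OCCCCCCCCC`, is not yet measured in this assay. It differs from compound 1 in one place: 2-hydroxy-3-((2-hydroxyethyl)amino)propyl in place of 4,6-diamino-2,3-dihydroxycyclohexyl on an oxygen on a saturated carbon. The two nonyl chains and the core of compound 1 stay as they are.

Among the compounds with values here, no step between measured compounds is available for this change, so there is nothing to scale it against. Since compound 1 gives 82.7% and compound 2, with a quite different set of groups, gives 86.9%, the expectation is that the step of a number 2.7 percentage points lower from compound 1 to compound 3 (within the scatter) stays within the scatter, in no particular direction. Compound 3 is estimated to give 80%, with a range from 62% to 98%.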

Compound 3, a percentage reported as activity, at one concentration (the size of the read-out at that concentration, not a potency): 99.1%
For compound 3 the middle estimate is 19.1 percentage points below the measured one, outside the stated range (above it).
By their numbers in this assay, from the lowest: compounds 1 and 2 (each within the scatter of the next); then compound 3.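

In this assay, the substituent on this oxygen on a saturated carbon turns out to matter: 2-hydroxy-3-((2-hydroxyethyl)amino)propyl in place of 4,6-diamino-2,3-dihydroxycyclohexyl gives a number 16.4 percentage points higher from compound 1 to compound 3 (beyond the scatter), which means a weaker effect at the one concentration tested. The two nonyl chains and the core stay the same through this step, so the shift belongs to this one place. Nothing measured on these compounds accounts for the shift.

The step swaps the ring and the whole substituent at once, so it does not tell whether the carbon ring or its amines carry the difference. Open too, on these data alone, is how a plain 2-aminoethyl group or a carboxylic acid on this oxygen would read, and whether the step holds with chains shorter than nonyl.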